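The source may hold more compounds than are shown below. What is called first, only, known or untested is meant among the compounds shown, and "the series" means these compounds.

In a functional assay on MCF7 cells (Homo sapiens) for antiproliferative activity, read by MTT assay, with a stated time of 48 h (on this read-out lower numbers stand for stronger inhibition and higher numbers for weaker inhibition), compound 2 `COCOC/C1=C/C[C@](C)(CCC=C(C)C)/C=C/[C@@H](OC(=O)C=C(C)C)[C@](C)(O)/C=C/C1=O` gives 3120 nM and compound 1 `CC(=O)OC/C1=C/C[C@](C)(CCC=C(C)C)/C=C/[C@@H](OC(=O)C=C(C)C)[C@](C)(O)/C=C/C1=O` gives 4510 nM. These two numbers lie within the usual scatter of each other, so neither compound can be ranked over the other. Compound 3 `CC(C)=CCC[C@]1(C)/C=C/[C@@H](OC(=O)C=C(C)C)[C@](C)(O)/C=C/C(=O)/C(COC(=O)c2ccc([N+](=O)[O-])cc2)=C\C1` changes that same oxygen again, with (4-nitrophenyl)carbonyl in place of methoxymethyl on an oxygen on a saturated carbon. Going by the values given here, one measured step bears on this change, a 1.4-fold lower number from compound 1 to compound 2 (0.16 log units; within the scatter), where methoxymethyl replaced acetyl on that oxygen. That single step stayed within the scatter, but neither group has an aromatic ring, so the data do not show what the entering group will do. No clear direction can be argued, and the expected 1.0-fold lower number from compound 2 to compound 3 (0.02 log units; within the scatter) is no step beyond the scatter. For compound 3, the expected value is 3000 nM, with an estimated range of 1000 nM to 9000 nM.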

Compound 3, half-maximal inhibitory concentration: 670 nM
Estimate against measurement, compound 3: 4.5-fold (0.65 log units) above; the measured number lies below the stated range.
By their numbers in this assay, from the lowest: compound 3; then compounds 2 and 1 (each within the scatter of the next).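

In this assay this oxygen on a saturated carbon proves able to change the number: with (4-nitrophenyl)carbonyl in place of methoxymethyl there is a 4.7-fold lower number from compound 2 to compound 3 (0.67 log units; beyond the scatter), whereas the earlier swap of acetyl for methoxymethyl stayed within the scatter. The same holds against the acetyl compound, where 4-nitrophenyl in place of methyl on a carbonyl carbon gives a 6.7-fold lower number from compound 1 to compound 3 (0.83 log units; beyond the scatter), so the group entering here stands apart from both smaller groups. Nothing available gives a reason for these steps.

Still open, going by these compounds, is what the aromatic ring and the nitro group each contribute, a question that a plain benzoyl group on this oxygen would address. Also open, on these data alone, is how a free hydroxyl group or a longer chain such as hexanoyl would behave at this place.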